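The compounds below may be only part of what the source reports. "The series", "measured", "known", "first", "only" and "open" are said of these compounds alone.

Measured compounds, with their values in an in vitro assay on HEK-tsA201 cells for antagonist activity at Neuronal acetylcholine receptor; alpha4/beta2 (Homo sapiens), read by fluorescence and calcium flux; a higher number here means a weaker inhibitor, a lower number a stronger inhibitor:
Compound 1 `CCCOc1ccc(C(=O)Nc2cccc(CC)n2)cc1`: compound 1 gives 37600 nM.
Compound 2 `CCCCNc1cccc(NC(=O)c2ccc(OCCC)cc2)n1`: compound 2 gives 54100 nM.
Compound 3 `CCCOc1ccc(C(=O)Nc2cccc(Nc3ccccc3F)n2)cc1`: for compound 3 the result is only a limit of the assay, > 100000 nM.

Compound 3 therefore stands at the limit of > 100000 nM in this assay, at which 1 of the 3 values shown sits, so its true value is not known, only that it lies beyond that point. The steps that lead to it are an at least 2.6-fold higher number from compound 1 to compound 3 (0.42 log units; beyond the scatter) and an at least 1.8-fold higher number from compound 2 to compound 3 (0.26 log units; that floor lies within the scatter), while a 1.4-fold higher number from compound 1 to compound 2 (0.16 log units; within the scatter). Both routes into compound 3 run toward weaker inhibition, though only one of them is beyond the scatter.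

Compound 4 `CCCOc1ccc(C(=O)Nc2cccc(Nc3ccc(Cl)cc3)n2)cc1` is not yet measured. It differs from compound 3 by 4-chlorophenyl in place of 2-fluorophenyl on a nitrogen on an aromatic ring. Among the measured compounds shown here, no measured step compares one arylamino group with another at this place, so the change itself is untested. Since compound 3 is already at the assay limit, compound 4 is expected to stay in the same region, with a step that the limit leaves unreadable from compound 3 to compound 4 amounting to no step beyond the scatter. The estimate for compound 4 in this assay is 150000 nM, within a range from 50000 nM to 500000 nM, most likely reported again only as a limit.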

Compound 4, half-maximal inhibitory concentration: > 100000 nM
Compound 4 was reported as a limit; the forecaster's own chance of this, stated with the estimate: 70%; the middle value lies beyond the limit too.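

Swapping 2-fluorophenyl for 4-chlorophenyl on the nitrogen leaves the compound at the top of the measurable range of this assay, and the step from compound 3 to compound 4 cannot be read because both are limits of the assay: the limit of > 100000 nM in this assay, at which 2 of the 4 values shown sit. Putting (4-chlorophenyl)amino in place of ethyl gives an at least 2.6-fold higher number from compound 1 to compound 4 (0.42 log units; beyond the scatter), while 4-chlorophenyl in place of butyl gives an at least 1.8-fold higher number from compound 2 to compound 4 (0.26 log units; that floor lies within the scatter). So a second aryl group at this place also gives a limit, whereas the ethyl and butylamino compounds gave readable values, and the loss seen with compound 3 is not tied to 2-fluorophenyl alone.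

As far as these compounds go, how far compound 3 and compound 4 lie past the limit stays unknown, so the two aryl groups cannot be ranked. From the compounds shown here alone, whether a benzylamino group or a plain amine at this place would return a readable value also stays open.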